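Acylguanidine sulfone series: aryl ether in place of biaryl

The source may report more compounds than this note shows. Statements on the series, on what has been measured and on what is new or still open speak of the compounds shown alone.

Measured compounds:
- compound 1 `CCN(CC)Cc1cc(Br)c(S(C)(=O)=O)cc1C(=O)N=C(N)N`: 9500 nM
- compound 2 `Cc1cc(-c2ccc(F)cc2)c(S(C)(=O)=O)cc1C(=O)N=C(N)N`: 36 nM

Within the data shown here, in a functional assay for inhibition of sodium/hydrogen exchanger (Oryctolagus cuniculus) (on this read-out lower numbers stand for stronger inhibition and higher numbers for weaker inhibition), compound 2 gives 36 nM and stands lowest of the two numbers so far; its nearest neighbour, compound 1, gives 9500 nM, a gap that lies beyond the scatter. The only difference between them is at the aromatic carbon bearing the 4-fluorophenyl group of compound 2 and the diethylaminomethyl group of compound 1, so the two numbers show that this position matters strongly.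

Compound 3 `Cc1cc(Oc2ccccc2)c(S(C)(=O)=O)cc1C(=O)N=C(N)N` keeps the core of compound 2 and changes only that position: phenoxy in place of 4-fluorophenyl on an aromatic carbon. Among the measured compounds shown here, no measured pair shows this kind of exchange, so its effect is open. A moderate loss against compound 2 is expected, a 2.5-fold higher number from compound 2 to compound 3 (0.40 log units; beyond the scatter), since nothing in the data shows whether the phenoxy group can match the 4-fluorophenyl group. Compound 3 is estimated at 90 nM in this assay, with a range from 25 nM to 350 nM.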

Compound 3, half-maximal inhibitory concentration: 10 nM
Compound 3: the middle estimate sits 9.0-fold (0.95 log units) above what was measured, outside the stated range (below it).
By their numbers in this assay, from the lowest: compound 3; then compound 2; then compound 1.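

In this assay, phenoxy in place of 4-fluorophenyl gives a 3.6-fold lower number from compound 2 to compound 3 (0.56 log units; beyond the scatter), so the aromatic carbon ortho to a methylsulfonyl group does not depend on a directly attached aromatic ring: a ring linked through oxygen is accepted there, and the number moves down. The exchange leaves the heavy-atom count of the group unchanged but replaces fluorine on the ring with a linking oxygen and adds a hydrogen-bond acceptor, and this single step cannot separate these changes. Nothing available explains the gain.

Open, going by these compounds, is whether plain phenyl or 4-fluorophenoxy at this position would show how much of the step belongs to the fluorine and how much to the oxygen. Also open, on these data alone, is whether a sulfur or amine link would serve in place of the oxygen, and how a carboxylic acid on the phenoxy ring would fare.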